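Removing a methyl from an aromatic oxygen: compound 2 to compound 4

The source may report more compounds than this note shows. Statements on the series, on what has been measured and on what is new or still open speak of the compounds shown alone.

Compounds measured so far:
compound 1 `COc1ccc(/C=C/C(=O)CC(C)=O)cc1OC` gives 4700 nM
compound 2 `COc1cc(/C=C/c2cc(C)no2)ccc1O` gives 33400 nM
compound 3 `CC(=O)CC(=O)/C=C/c1ccc(O)cc1` gives 36500 nM

These three were tested in a functional assay on HCT-116 cells (Homo sapiens) for cytotoxicity, read by MTT assay, with a stated time of 72 h; on this read-out lower numbers stand for stronger inhibition and higher numbers for weaker inhibition. Among them, compound 2 stands second highest of the three numbers. Its nearest neighbour is compound 3, whose value is within the usual scatter of that of compound 2, so no order can be read between those two. Compound 1 stands well apart, with a value beyond the scatter from compound 2, and it is the only one of the three that differs clearly from the others.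

Compound 4 `Cc1cc(/C=C/c2ccc(O)c(O)c2)on1` has not yet been measured. It is derived from compound 2 by a single change: hydrogen in place of methyl on an oxygen on an aromatic ring. The change is small, removing only one carbon and adding no new ring or charge.

Going by the values given here, no measured pair in this set differs by the same change, so there is no direct precedent to lean on. The expected step in this assay is therefore a modest one, in no definite direction, likely staying within the scatter: a 1.1-fold lower number from compound 2 to compound 4 (0.05 log units; within the scatter). On that basis compound 4 is estimated at 30000 nM, within a range from 10000 nM to 90000 nM.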

Compound 4, half-maximal inhibitory concentration: 5300 nM
Estimate against measurement, compound 4: 5.7-fold (0.75 log units) above; measured number outside the range, below it.
By their numbers in this assay, from the lowest: compounds 1 and 4 (each within the scatter of the next); then compounds 2 and 3 (each within the scatter of the next).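

In this assay, replacing the methoxy with a hydroxy on the aromatic ring gives a 6.3-fold lower number from compound 2 to compound 4 (0.80 log units; beyond the scatter). Going by these compounds alone, this is the first step here that can be tied to one change, since no two earlier compounds differed in only one place. It shows that this oxygen is a sensitive position, where losing a single carbon moves the number beyond the scatter, although nothing available explains why.

Within the data shown here, it remains open whether hydrogen is the only group on this oxygen that gives the lower number, or whether a slightly larger group, such as an ethyl or an acetyl, would do the same. It is also unknown whether the same change would produce a similar step on the methoxy groups of compound 1, whose core is different.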